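Oxime series: furan-2-yl in place of 4-methoxyphenyl

The source may hold more compounds than are shown below. What is called first, only, known or untested is meant among the compounds shown, and "the series" means these compounds.

Within the data shown here, the two measured members share an amide-linked core and differ at both ends. Compound 1 `CC(=O)c1ccc(OCC(=O)Nc2ccc(C(=O)/C=C/c3ccco3)cc2)cc1` carries an acetyl group and a furan-2-yl chain terminus; compound 2 `COc1ccc(/C=C/C(=O)c2ccc(NC(=O)COc3ccc(/C(C)=N\O)cc3)cc2)cc1` carries the oxime and a 4-methoxyphenyl terminus. In a functional assay on the whole organism (strain albino) for inhibition, with Rattus norvegicus as the target, read by paw edema, with stated times of 30 min and 4 h, at a dose of 100 mg/kg by the oral route (on this read-out lower numbers stand for less inhibition and higher numbers for more inhibition at the one dose given (going by the name of the read-out)), compound 1 gives 39%, and in this assay compound 2 gives 42%. Compound 2 stands alongside compound 1, the two numbers within the scatter of each other, so no order between them can be read.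

Compound 3 `C/C(=N/O)c1ccc(OCC(=O)Nc2ccc(C(=O)/C=C/c3ccco3)cc2)cc1` keeps the oxime of compound 2 and changes only the chain terminus: furan-2-yl in place of 4-methoxyphenyl on a double-bonded chain carbon bound to a double-bonded chain carbon. Among the measured compounds shown here, no step between measured compounds covers this change on its own. Compound 1, which already carries the furan-2-yl terminus on the acetyl core, gives 39%, a number in the same range as compound 2. On that basis no shift beyond the scatter is expected in this assay, in either direction.

Compound 3 is therefore estimated at 40%, within 28% to 52%, an expected step of a number 2 percentage points lower from compound 2 to compound 3 (within the scatter).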

Compound 3, a percentage reported as inhibition, in the whole organism at one dose (the size of the read-out at that dose, not a potency): 48%
For compound 3 the middle estimate is 8 percentage points below the measured one; measured number inside the range.
By their numbers in this assay, from the lowest: compounds 1, 2 and 3 (each within the scatter of the next).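

In this assay the change from 4-methoxyphenyl to furan-2-yl on a double-bonded chain carbon bound to a double-bonded chain carbon now has a direct reading with the oxime held in place: the step is a number 6 percentage points higher from compound 2 to compound 3 (within the scatter) and shows that this position accepts the five-membered aromatic ring in place of the six-membered one with no shift that can be told from the scatter. The oxime end gets its first single-place reading with the furan-2-yl terminus held in place: the step is a number 9 percentage points higher from compound 1 to compound 3 (within the scatter) and shows that the group of 4 heavy atoms in place of the group of 3 heavy atoms on an aromatic carbon cannot be separated from the scatter either. No measurement at hand bears on what lies behind these numbers.

Open, going by these compounds, is whether any terminus at this chain position, such as a thiophen-2-yl, a pyridin-3-yl or an unsubstituted phenyl, would give a step beyond the scatter. Equally open, on these data alone, is what a carboxylic acid or an amine would do on the aromatic carbon that carries the oxime.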